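The compounds below may be only part of what the source reports. "The series", "measured", "known", "first", "only" and "open" are said of these compounds alone.

Measured so far:
Compound 1, `C=CCn1ncc2c(C)nc(CC)n2c1=O`. In a functional assay for inhibition, with Homo sapiens as the target (on this read-out lower numbers stand for stronger inhibition and higher numbers for weaker inhibition), compound 1 gives > 48000 nM, which is a limit of the assay and not a number.
Compound 2, `C=CCn1ncc2c(C)nc(CCC)n2c1=O`. In this assay compound 2 gives 40000 nM.
Compound 3, `CCc1nc(C)c2cnnc(S)n12`. In this assay compound 3 gives > 48000 nM, again a limit of the assay and not a number.

Compound 4, `Cc1nc(C(C)C)n2c(S)nncc12`, has not yet been measured. It differs from compound 3 by one change: methyl in place of hydrogen on a saturated chain carbon bound to an aromatic carbon and a saturated chain carbon. The same kind of change is seen between two measured compounds, (methyl in place of hydrogen on a saturated chain carbon, two bonds along the chain from an aromatic carbon), though there the place is two bonds along the chain from an aromatic carbon, whereas in compound 4 it is bound to an aromatic carbon and a saturated chain carbon. That measured step is an at least 1.2-fold lower number from compound 1 to compound 2 (0.07 log units; that floor lies within the scatter). The difference between the core of compound 1 and the core of compound 3 is not broken down here.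

Because (the limit of > 48000 nM in this assay, at which 2 of the 3 values shown sit), and because the earlier step is an at least 1.2-fold lower number from compound 1 to compound 2 (0.07 log units; that floor lies within the scatter), the step from compound 3 to compound 4 in this assay is expected to be small, around a step that the limit leaves unreadable from compound 3 to compound 4. Compound 4 is therefore estimated at 60000 nM, most likely again reported only as a limit.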

Compound 4, half-maximal inhibitory concentration: > 48000 nM
Compound 4: no number, only a limit (the forecaster's own chance of this, stated with the estimate: 75%); the middle value does not contradict the limit.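

No step from compound 3 to compound 4 can be read in this assay, because the value of each compound is a limit of the assay and not a number: the limit of > 48000 nM in this assay, at which 3 of the 4 values shown sit.

The compounds shown leave open whether going from ethyl to isopropyl on the core of compound 3 changes inhibition at all.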